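Swapping the Hydroxyphenyl Arm of Compound 3

The source may hold more compounds than are shown below. What is called first, only, known or untested is meant among the compounds shown, and "the series" means these compounds.

Three compounds share one core and differ only in the aryl ring attached to the carbon that carries a double bond to nitrogen. In a functional assay, with a stated time of 30 min (on this read-out lower numbers stand for stronger inhibition and higher numbers for weaker inhibition), compound 1 `CCCCc1oc2ccc(/N=C/c3ccc(C#N)cc3)cc2c1C(=O)c1ccc(OC)cc1` gives 27.2 ug/mL, compound 2 `CCCCc1oc2ccc(/N=C/c3cccc([N+](=O)[O-])c3)cc2c1C(=O)c1ccc(OC)cc1` gives 34.2 ug/mL, and compound 3 `CCCCc1oc2ccc(/N=C/c3ccccc3O)cc2c1C(=O)c1ccc(OC)cc1` gives 99.4 ug/mL. Compound 3 thus has the highest number of the three and so the weakest inhibition: a 3.7-fold higher number from compound 1 to compound 3 (0.56 log units; beyond the scatter) and a 2.9-fold higher number from compound 2 to compound 3 (0.46 log units; beyond the scatter) both lie beyond the scatter, while a 1.3-fold higher number from compound 1 to compound 2 (0.10 log units; within the scatter) does not.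

Compound 4 `CCCCc1oc2ccc(/N=C/c3ccc(OCC)c(OC)c3)cc2c1C(=O)c1ccc(OC)cc1` continues from compound 3 with one change: 4-ethoxy-3-methoxyphenyl in place of 2-hydroxyphenyl on a carbon with a double bond to nitrogen. The measured steps that bear on it are the two leading into compound 3, since each exchanges a differently substituted phenyl for the 2-hydroxyphenyl and each raises the number. Within the data shown here, no measured compound carries the 4-ethoxy-3-methoxyphenyl ring, so the only guide is that moving away from the 2-hydroxyphenyl has, in both known cases, corresponded to a number in the range of compound 1 and compound 2. A modest fall in this assay is therefore expected for compound 4, roughly a 2.5-fold lower number from compound 3 to compound 4 (0.40 log units; beyond the scatter), though with wide uncertainty. The estimate for compound 4 is 40 ug/mL, within a range from 18 ug/mL to 90 ug/mL.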

Compound 4, half-maximal inhibitory concentration: 14.8 ug/mL
Estimate against measurement, compound 4: 2.7-fold (0.43 log units) above; measured number outside the range, below it.
By their numbers in this assay, from the lowest: compounds 4, 1 and 2 (each within the scatter of the next, the first and the last beyond it); then compound 3.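

In this assay, a 6.7-fold lower number from compound 3 to compound 4 (0.83 log units; beyond the scatter), the largest step yet seen at this position, so a ring with 11 heavy atoms and two alkoxy groups, ethoxy and methoxy, gives a lower number than the 7-atom 2-hydroxyphenyl it replaces. The change also separates compound 4 from the nitro-bearing ring, with a 2.3-fold lower number from compound 2 to compound 4 (0.36 log units; beyond the scatter), whereas a 1.8-fold lower number from compound 1 to compound 4 (0.26 log units; within the scatter) lies within the scatter, so compound 4 and compound 1 cannot be ranked against each other, and the larger ring shows no penalty against the smaller 4-cyanophenyl. No measurement of any other property accompanies these numbers, so nothing here explains the size of the step.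

This one step removes the hydroxyl and adds the ethoxy and methoxy groups together, so the compounds shown cannot say how much of the change belongs to each, and a plain phenyl ring or a ring with methoxy alone would be needed to pull these apart. From the compounds shown here alone, how far the position goes on tolerating added bulk, for example with a longer butoxy chain, and how it responds to an amine or a carboxylic acid on the ring also remain open.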